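Swapping the aryl group on the benzylic amine of a quinolinone core

A few compounds are considered here, and "the series" means these few. Any claim that something is new, unique, unknown or untested is made for them only; others in the source may bear on it.

Measured compounds:
compound 1 `CCCn1ccc2c(NCCCc3ccccc3)cccc2c1=O` gives 158 nM
compound 2 `CCCn1ccc2c(NCc3cccc(OC)c3)cccc2c1=O` gives 316 nM
compound 3 `CCCn1ccc2c(NCc3cccc(OC(F)(F)F)c3)cccc2c1=O` gives 200 nM

All three share one core and differ only in the group carried on a saturated chain carbon bound to a nitrogen on an aromatic ring. In a functional assay on CHO cells for positive allosteric modulation of metabotropic glutamate receptor 2 (Homo sapiens), read by scintillation counting and GTPgammaS binding, with a stated time of 30 min (on this read-out lower numbers stand for an effect already at smaller amounts and higher numbers for an effect only at larger amounts of compound), compound 2 stands apart from neither neighbour: the step of a 2.0-fold higher number from compound 1 to compound 2 (0.30 log units; within the scatter) and the step of a 1.6-fold lower number from compound 2 to compound 3 (0.20 log units; within the scatter) are both within the scatter, so the three numbers cannot be put in order.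

Compound 4 `CCCn1ccc2c(NCc3ccccc3Cl)cccc2c1=O` differs from compound 2 by 2-chlorophenyl in place of 3-methoxyphenyl on a saturated chain carbon bound to a nitrogen on an aromatic ring. The change resembles the steps already seen, where one aryl group was traded for another or a methyl for a trifluoromethyl without a shift beyond the scatter. On that basis no step beyond the scatter is expected for compound 4 in this assay, and the estimated step of a 1.3-fold lower number from compound 2 to compound 4 (0.10 log units; within the scatter) is small. Compound 4 is therefore expected to give about 250 nM, within a range from 100 nM to 700 nM.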

Compound 4, half-maximal effective concentration: 200 nM
Compound 4: middle estimate off by 1.3-fold (0.10 log units), on the high side, within the range that was stated.
By their numbers in this assay, from the lowest: compounds 1, 3, 4 and 2 (each within the scatter of the next).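

In this assay, the place on a saturated chain carbon bound to a nitrogen on an aromatic ring also accepts a chlorine-bearing aryl group: the step of a 1.6-fold lower number from compound 2 to compound 4 (0.20 log units; within the scatter) and the step of a 1.3-fold higher number from compound 1 to compound 4 (0.10 log units; within the scatter) both lie within the scatter. Compound 4 has 0 hydrogen-bond acceptors in this group where compound 2 has 1, so among these two compounds, an oxygen-bearing group with an acceptor is not needed for a number in this range. Nothing measured here accounts for how little the number moves across these swaps.

The change from 3-methoxyphenyl to 2-chlorophenyl alters both the substituent and its location on the ring, so the two effects cannot be separated; 3-chlorophenyl would separate them. On these data alone, what an amine or a carboxylic acid on this ring would do also stays open.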